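Aryl Swap on the Shared Core: Expected Cytotoxicity

A few compounds are considered here, and "the series" means these few. Any claim that something is new, unique, unknown or untested is made for them only; others in the source may bear on it.

Measured compounds:
compound 1 `Cc1ccc(C)c(-c2nc(CN3CCC(C(=O)NCCCN4C[C@H](C)C[C@H](C)C4)CC3)c(C)o2)c1` — 4070 nM
compound 2 `Cc1ccccc1-c1nc(CN2CCC(C(=O)NCCCN3CCC(C)(C)CC3)CC2)c(C)o1` — 10200 nM
compound 3 `Cc1ccccc1-c1nc(CN2CCC(C(=O)NCCCN3CC4CCCC(C4)C3)CC2)c(C)o1` — 10900 nM

All three were tested in an ADME assay on Huh7.5.1 cells (Homo sapiens) for cytotoxicity, read by ATP content, with a stated time of 48 h; on this read-out higher numbers stand for lower toxicity in this test and lower numbers for higher toxicity in this test. Compound 1 stands lowest of the three numbers with 4070 nM; compound 2 sits beyond the scatter above it, and compound 3 lies furthest away, also beyond the scatter. Compound 1 differs from compound 2 in two places at once, so the gap between them cannot be assigned to either.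

Within the data shown here, the only single-point step in the set is a 1.1-fold higher number from compound 2 to compound 3 (0.03 log units; within the scatter), which concerns the saturated amine ring at the far end of the chain and not the aryl group on the shared core.

Compound 4 `CCc1ccccc1-c1nc(CN2CCC(C(=O)NCCCN3C[C@H](C)C[C@H](C)C3)CC2)c(C)o1` is the next compound. It differs from compound 1 in one place: 2-ethylphenyl in place of 2,5-dimethylphenyl on an aromatic carbon. Among the measured compounds shown here, no measured step touches this aryl position, so the available data give no direct guide to its effect. Without such a precedent, the step is expected to be small, and compound 4 is expected to remain close to compound 1 in this assay, with a 1.4-fold higher number from compound 1 to compound 4 (0.13 log units; within the scatter). The estimate for compound 4 is therefore 5500 nM, with a range from 2500 nM to 12000 nM.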

Compound 4, half-maximal cytotoxic concentration: 9320 nM
The estimate for compound 4 lay 1.7-fold (0.23 log units) below the measured number; measured number inside the range.
By their numbers in this assay, from the lowest: compound 1; then compounds 4, 2 and 3 (each within the scatter of the next).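

Among these compounds, replacing 2,5-dimethylphenyl with 2-ethylphenyl on the aromatic carbon of the shared core gives a 2.3-fold higher number from compound 1 to compound 4 (0.36 log units; beyond the scatter) in this assay and so shows that this aryl position can shift the number by more than the scatter, which the earlier compounds could not show. The group that leaves and the group that enters have the same count of heavy atoms, all carbon, and each has one six-membered aromatic ring of carbon only, so a change in how these carbons are joined is enough for a step of this size. No measurement shown here gives a reason for the step.

Going by these compounds, it remains open whether the step goes with losing the second methyl group or with lengthening the other substituent to ethyl, and 2-methylphenyl on the core of compound 1 would separate the two. Also open, on these data alone, are how 2-isopropylphenyl or 2-methoxyphenyl would stand at this position, and whether the same aryl change gives a similar step with the amine ends of compound 2 and compound 3.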